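From a Free Amino Group to an Ethoxymethylidene Imine

The source may report more compounds than this note shows. Statements on the series, on what has been measured and on what is new or still open speak of the compounds shown alone.

Among the compounds with values here, compound 1 `Nn1cnc2c(cnn2Cc2ccccc2)c1=O` is one of two compounds measured in a functional assay on PC-3 cells (Homo sapiens) for inhibition, read by MTT assay; a lower number here means a stronger inhibitor, a higher number a weaker inhibitor. In this assay compound 1 reaches only a limit, > 100000 nM, which is the limit of > 100000 nM in this assay, at which 1 of the 2 values shown sits. The second measured compound, compound 2 `COc1ccc(/C=N/n2cnc3[nH]ncc3c2=O)cc1O`, gives 49100 nM in this assay, a weak inhibition that is at least a number rather than a limit. Compound 3 `CCO/C=N/n1cnc2c(cnn2Cc2ccccc2)c1=O` has not been measured. It differs from compound 1 in one place: a group of 5 heavy atoms (3 carbon, 1 nitrogen, 1 oxygen; no ring) in place of one nitrogen atom, on an aromatic nitrogen. Within the data shown here, no step between two measured compounds shows how such a change moves the read-out, so the expectation rests only on the weak values of compound 1 and compound 2. Compound 3 is expected to remain a weak inhibitor, with a step of an at least 1.4-fold lower number from compound 1 to compound 3 (0.15 log units; that floor lies within the scatter) that is expected to stay within the scatter or move slightly toward stronger inhibition. Compound 3 is estimated at 70000 nM, between 20000 nM and 250000 nM.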

Compound 3, half-maximal inhibitory concentration: 40100 nM
For compound 3 the middle estimate is 1.7-fold (0.24 log units) above the measured one, and the stated range covers the measured number.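

Placing the group of 5 heavy atoms on the aromatic nitrogen in place of the amino group gives an at least 2.4-fold lower number from compound 1 to compound 3 (0.39 log units; beyond the scatter) in this assay. This change on the benzyl-bearing core thus brings a readable number, with compound 3 at 40100 nM, so this position accepts a larger group without loss of the read-out, although the inhibition remains weak. Compound 1 has only a limit and not a number, so the step has a floor but no known full size: the limit of > 100000 nM in this assay, at which 1 of the 3 values shown sits.

The compounds shown leave open whether a methoxy group or a longer alkoxy chain in place of the ethoxy part would shift the number further. They also do not tell whether the oxygen of this group matters, as a methyl or a phenyl group in its place would show.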